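Varying the Amine on the Sulfonyl Sulfur

This account rests on a few compounds, and the source may have more. Where it says the series, first, only, none or still open, it means among the compounds named here.

Three acids built on one shared core have been measured in an assay on CHO cells for displacement of a labelled ligand from prostaglandin D2 receptor 2 (Homo sapiens), read by scintillation counting; on this read-out lower numbers stand for stronger inhibition and higher numbers for weaker inhibition. Compound 1 `COCCNS(=O)(=O)c1ccc(C)c(C#Cc2cc(Cl)ccc2OCC(=O)O)c1` gives 3.6 nM, compound 2 `Cc1ccc(S(=O)(=O)N(C)C)cc1C#Cc1cc(Cl)ccc1OCC(=O)O` gives 5 nM, and compound 3 `CCN(CC)S(=O)(=O)c1ccc(C)c(C#Cc2cc(Cl)ccc2OCC(=O)O)c1` gives 3.4 nM. The steps of a 1.4-fold higher number from compound 1 to compound 2 (0.14 log units; within the scatter), a 1.1-fold lower number from compound 1 to compound 3 (0.02 log units; within the scatter) and a 1.5-fold lower number from compound 2 to compound 3 (0.17 log units; within the scatter) all stay within the scatter, so compound 3 stands level with the other two rather than apart from them. Compound 4 `Cc1ccc(S(=O)(=O)N(C)CC(C)C)cc1C#Cc1cc(Cl)ccc1OCC(=O)O` differs from compound 3 in one place: isobutyl(methyl)amino in place of diethylamino on a sulfonyl sulfur. Every earlier exchange of the amine on this sulfonyl sulfur left this assay unchanged beyond scatter, so for compound 4 a step of a 1.1-fold higher number from compound 3 to compound 4 (0.05 log units; within the scatter) is expected, none beyond the scatter. Compound 4 is therefore estimated at 3.8 nM, with a range from 1.6 nM to 9 nM.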

Compound 4, inhibition constant: 4.2 nM
Compound 4: the middle estimate sits 1.1-fold (0.04 log units) below what was measured; low and high end bracket the measured number.
By their numbers in this assay, from the lowest: compounds 3, 1, 4 and 2 (each within the scatter of the next).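

The amine on the sulfonyl sulfur also accepts a branched chain: isobutyl(methyl)amino stays within the scatter of diethylamino (a 1.2-fold higher number from compound 3 to compound 4 (0.09 log units; within the scatter)) and of (2-methoxyethyl)amino (a 1.2-fold higher number from compound 1 to compound 4 (0.07 log units; within the scatter)) in this assay. Adding isopropyl to the saturated chain carbon bound to a sulfonamide nitrogen also moves the number only within the scatter (a 1.2-fold lower number from compound 2 to compound 4 (0.08 log units; within the scatter)). No available evidence explains this flat response. As far as these compounds go, whether a ring amine such as morpholine or piperidine, or an unsubstituted amino group, would stay equally close remains open.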